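Adding a hydroxybutyl chain to the free amine of compound 3

The compounds below may be only part of what the source reports. "The series", "measured", "known", "first", "only" and "open" are said of these compounds alone.

Measured compounds:
- compound 1, `CCOC(=O)CNC(C)(C)CC(=O)N[C@@H]1CCc2ccccc2N(Cc2ccc(-c3ccccc3-c3nn[nH]n3)cc2)C1=O`: 56 nM in a functional assay (Pituitary gland cell) with Rattus norvegicus as the target; on this read-out lower numbers stand for an effect already at smaller amounts and higher numbers for an effect only at larger amounts of compound
- compound 2, `CC(C)(CC(=O)N[C@@H]1CCc2ccccc2N(Cc2ccc(-c3ccccc3-c3nn[nH]n3)cc2)C1=O)NCCO`: 30 nM in this assay
- compound 3, `CC(C)(N)C(=O)N[C@@H]1CCc2ccccc2N(Cc2ccc(-c3ccccc3-c3nn[nH]n3)cc2)C1=O`: 30 nM in this assay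

All three compounds share the same core and differ only in the amide side chain. Compound 3 stands level with compound 2 at the digits shown, and the two together give the lowest numbers of the three; compound 1 gives a somewhat higher number, but its step to compound 3 lies within the scatter. Compound 4, `C[C@@H](O)CCNC(C)(C)C(=O)N[C@@H]1CCc2ccccc2N(Cc2ccc(-c3ccccc3-c3nn[nH]n3)cc2)C1=O`, carries 3-hydroxybutyl in place of hydrogen on an amine nitrogen. Within the data shown here, two measured steps bear on this change. The step of a 1.9-fold lower number from compound 1 to compound 2 (0.27 log units; within the scatter) swapped one group for another on the carbon chain bound to the amine nitrogen, and the step of no change at the digits printed from compound 2 to compound 3 (within the scatter) stripped a hydroxyethyl-bearing chain back to a free amine; neither moved the number beyond the scatter. A hydroxybutyl group on the amine nitrogen of compound 3 is therefore expected to leave this assay essentially where it is, a 1.1-fold higher number from compound 3 to compound 4 (0.03 log units; within the scatter). Compound 4 is expected to give about 32 nM, within a range from 14 nM to 70 nM.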

Compound 4, concentration for half-maximal effect: 100 nM
The estimate for compound 4 lay 3.1-fold (0.49 log units) below the measured number; measured number outside the range, above it.
By their numbers in this assay, from the lowest: compounds 2, 3, 1 and 4 (each within the scatter of the next, the first and the last beyond it).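

In this assay, among these compounds, this amine nitrogen proves less tolerant than the earlier steps suggested: placing 3-hydroxybutyl in place of hydrogen gives a 3.3-fold higher number from compound 3 to compound 4 (0.52 log units; beyond the scatter), a modest change but the first to pass beyond the scatter. The longer side chain bearing a 2-hydroxyethyl group sits equally far from the new compound, with a 3.3-fold higher number from compound 2 to compound 4 (0.52 log units; beyond the scatter), while the ester-bearing side chain stays close, with a 1.8-fold higher number from compound 1 to compound 4 (0.25 log units; within the scatter), which lies within the scatter. Nothing measured here gives a cause for these steps.

A plain butyl group or a 2-hydroxyethyl group on this same amine nitrogen would help separate the part played by the chain from that played by its hydroxyl. On these data alone, whether the defined stereocentre of the 3-hydroxybutyl group matters also remains open.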